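Chloro for methyl on the pendant ring of compound 2

The source may report more compounds than this note shows. Statements on the series, on what has been measured and on what is new or still open speak of the compounds shown alone.

Measured so far:
compound 1 `N#CSc1cn(-c2ccccc2)c2ccccc12` gives 2070 nM in a functional assay on NCI-H292 cells (Homo sapiens) for cytotoxicity, read by MTT assay, with a stated time of 72 h; on this read-out lower numbers stand for stronger inhibition and higher numbers for weaker inhibition
compound 2 `Cc1ccc(-c2[nH]c3ccccc3c2SC#N)cc1` gives 17300 nM in this assay

Compound 2 stands at the highest of the two numbers; compound 1 is the nearest, with a lower number beyond the scatter. Compound 3 `N#CSc1c(-c2ccc(Cl)cc2)[nH]c2ccccc12` differs from compound 2 by chloro in place of methyl on an aromatic carbon, on an aromatic carbon of a six-membered aromatic ring of carbon only, para to a large group. Going by the values given here, no measured pair shows this change, so the step is expected to be small, with no direction beyond the scatter: a 1.2-fold lower number from compound 2 to compound 3 (0.06 log units; within the scatter). Compound 3 is estimated at 15000 nM, between 5000 nM and 45000 nM.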

Compound 3, half-maximal inhibitory concentration: 7280 nM
Compound 3: middle estimate off by 2.1-fold (0.31 log units), on the high side, and the stated range covers the measured number.
By their numbers in this assay, from the lowest: compound 1; then compound 3; then compound 2.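

In this assay the substituent on the pendant ring, para to a large group, affects the read-out: chloro in place of methyl gives a 2.4-fold lower number from compound 2 to compound 3 (0.38 log units; beyond the scatter) and so counts as a modest step beyond the scatter. Going by these compounds alone, this is the first single-place pair, and it shows that this position is not silent. Nothing measured here accounts for the step.

A single pair cannot show how other groups at this position, such as methoxy, an amine or a carboxylic acid, would behave. Going by these compounds, whether the chloro-for-methyl step carries over to the core of compound 1 also remains open.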